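The source may report more compounds than this note shows. Statements on the series, on what has been measured and on what is new or still open speak of the compounds shown alone.

Compound 1 `Cc1nc2cc(C(=O)NN)c([N+](=O)[O-])cc2[nH]1`: in a functional assay on A549 cells (Homo sapiens) for cytotoxicity, read by resazurin assay, with a stated time of 72 h (a lower number here means a stronger inhibitor, a higher number a weaker inhibitor), compound 1 gives > 100000 nM, which is a limit of the assay.
Compound 2 `CC(C)=NNC(=O)c1cc2nc(C)[nH]c2cc1[N+](=O)[O-]`: in this assay compound 2 gives > 100000 nM, again a limit.
Compound 3 `Cc1nc2cc(C(=O)N/N=C\c3ccc(C)o3)c([N+](=O)[O-])cc2[nH]1`: in this assay compound 3 gives > 100000 nM, also a limit.

Compound 3 therefore stands at the limit of > 100000 nM in this assay, at which 3 of the 3 values shown sit, and no value shown is a number. The steps among the measured compounds, a step that the two limits leave unreadable from compound 1 to compound 2, a step that the two limits leave unreadable from compound 1 to compound 3 and a step that the two limits leave unreadable from compound 2 to compound 3, each run from one limit to another, so their sizes cannot be read; they say only that replacing the terminal nitrogen of the hydrazide with either of the two groups did not bring the potency below the limit.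

Compound 4 `Cc1nc2cc(C(=O)N/N=C\c3c[nH]c4ccccc34)c([N+](=O)[O-])cc2[nH]1` has not yet been measured. It differs from compound 3 by 1H-indol-3-yl in place of 5-methylfuran-2-yl on a carbon with a double bond to nitrogen. Going by the values given here, no measured step alters the group on that carbon with a readable outcome, so the measured steps bear on this change only in showing that every variant so far stayed at the limit. The step in this assay is thus expected to be small or absent beyond the scatter, in no readable direction. Compound 4 is expected to give about 100000 nM, in a range from 20000 nM to 300000 nM. The estimated step is then a number no higher from compound 3 to compound 4 (the limit leaves the size open), with the most likely result being another limit.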

Compound 4, half-maximal inhibitory concentration: > 100000 nM
Compound 4: no number, only a limit; the forecaster's own chance of this, stated with the estimate: 75%; the middle value sits exactly at the limit.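

Compound 3 and compound 4 both rest on a limit and not on a number in this assay, so the step between them cannot be read: the limit of > 100000 nM in this assay, at which 4 of the 4 values shown sit. The compounds shown leave open what change, if any, would bring a measurable potency in this assay.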